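The source may report more compounds than this note shows. Statements on the series, on what has been measured and on what is new or still open speak of the compounds shown alone.

Compound 1 `CCCCNS(=O)(=O)c1ccc(Nc2ncc3c(n2)N(C2CCCC2)[C@H](CC)C(=O)N3C)cc1` and compound 2 `CCCNS(=O)(=O)c1ccc(Nc2ncc3c(n2)N(C2CCCC2)[C@H](CC)C(=O)N3C)cc1` share one core and differ in a single place: methyl in place of hydrogen on a saturated chain carbon, three bonds along the chain from a sulfonamide nitrogen. In an assay for inhibition of serine/threonine-protein kinase PLK2 (Homo sapiens), read by FRET and Z'-LYTE, with a stated time of 1 h (on this read-out lower numbers stand for stronger inhibition and higher numbers for weaker inhibition), compound 2 gives 17.8 nM, and compound 1 gives 19.9 nM. That step, a 1.1-fold higher number from compound 2 to compound 1 (0.05 log units; within the scatter), is too small to count as a real change.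

Compound 3 `CCCNC(=O)c1ccc2c(ccn2-c2ncc3c(n2)N(c2ccn(C)n2)C(CC)C(=O)N3C)c1` is built on a different core; how the two cores differ is not broken down here. In this assay compound 3 gives 207 nM, the highest number of the three, with compound 1 and compound 2 both beyond the scatter from it.

Compound 4 `CCCCNC(=O)c1ccc2c(ccn2-c2ncc3c(n2)N(c2ccn(C)n2)C(CC)C(=O)N3C)c1` has not yet been measured. It differs from compound 3 by methyl in place of hydrogen on a saturated chain carbon, three bonds along the chain from an amide-type nitrogen. Among the compounds with values here, this is the same kind of change as the one between compound 2 and compound 1, but not the same: there the chain carbon sits three bonds along the chain from a sulfonamide nitrogen, here three bonds along the chain from an amide-type nitrogen. In this assay only a small step is expected, a 1.0-fold lower number from compound 3 to compound 4 (0.01 log units; within the scatter), because a 1.1-fold higher number from compound 2 to compound 1 (0.05 log units; within the scatter) lay within the scatter. Compound 4 is therefore estimated at 200 nM, with a likely range from 100 nM to 400 nM.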

Compound 4, half-maximal inhibitory concentration: 159 nM
For compound 4 the middle estimate is 1.3-fold (0.10 log units) above the measured one; the range from low to high includes it.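

The methyl on a saturated chain carbon, three bonds along the chain from an amide-type nitrogen, gives a 1.3-fold lower number from compound 3 to compound 4 (0.11 log units; within the scatter), so in this assay this change is again too small to count as real, and the two cores agree: the same change on two cores in this assay, a 1.1-fold higher number (0.05 log units; within the scatter) from compound 2 to compound 1 and a 1.3-fold lower number (0.11 log units; within the scatter) from compound 3 to compound 4, 1.5-fold (0.16 log units) apart, within the scatter of two such steps Within these two pairs, then, the change carries from one core to the other in the sense that it stays within the scatter on both. Within the data shown here, this does not show that it would do so on every core, since there are only two pairs and their chains sit on different groups, one a sulfonamide and the other an amide-type nitrogen, and steps this small could also hide a slight real effect.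

The compounds shown leave open whether a longer chain, such as pentyl, would also stay within the scatter of butyl. They also leave open what a chain ending in an amine or a carboxylic acid would do in this assay.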